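Swapping the triazole aryl on the free phenol core

The source may hold more compounds than are shown below. What is called first, only, known or untested is meant among the compounds shown, and "the series" means these compounds.

Measured compounds in a functional assay on MCF7 cells (Homo sapiens) for cytotoxicity, read by MTT assay, with a stated time of 4 days; on this read-out lower numbers stand for stronger inhibition and higher numbers for weaker inhibition:
compound 1 `C=C1C(=O)[C@]23C[C@@]1(O)CC[C@H]2c1ccc(OS(=O)(=O)c2ccc(C)cc2)c(C)c1[C@@H]3Cn1cc(-c2ccccn2)nn1`, 320 nM;
compound 2 `C=C1C(=O)[C@]23C[C@@]1(O)CC[C@H]2c1ccc(O)c(C)c1[C@@H]3Cn1cc(-c2ccccn2)nn1`, 2240 nM;
compound 3 `C=C1C[C@]23C[C@@]1(O)CC[C@H]2c1ccc(OS(=O)(=O)c2ccc(C)cc2)c(C)c1[C@@H]3Cn1cc(-c2ccc(C)cc2)nn1`, for which only a limit of > 20000 nM is reported.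

Compound 2 gives the highest of the two numbers in this assay; its nearest neighbour is compound 1, reached by the step of a 7.0-fold higher number from compound 1 to compound 2 (0.85 log units; beyond the scatter). Compound 3 sits at the limit of > 20000 nM in this assay, at which 1 of the 3 values shown sits, and as a limit it offers no number to compare.

Compound 4 `C=C1C(=O)[C@]23C[C@@]1(O)CC[C@H]2c1ccc(O)c(C)c1[C@@H]3Cn1cc(-c2ccc(C(F)(F)F)cc2)nn1` differs from compound 2 in one place: 4-(trifluoromethyl)phenyl in place of pyridin-2-yl on an aromatic carbon. Within the data shown here, no measured step changes the group on this triazole carbon while leaving the rest of the core untouched, so none bears directly on this change. Compound 3 carries a different aryl at that position, but it also differs elsewhere, so its limit cannot be tied to the aryl alone. Among the measured compounds shown here, with no bearing step, a shift of modest size in either direction, or none beyond the scatter, is expected. The estimate for compound 4 in this assay is 3000 nM, with a range from 900 nM to 10000 nM, which corresponds to an expected step of a 1.3-fold higher number from compound 2 to compound 4 (0.13 log units; within the scatter).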

Compound 4, half-maximal inhibitory concentration: 1840 nM
Estimate against measurement, compound 4: 1.6-fold (0.21 log units) above, within the range that was stated.
By their numbers in this assay, from the lowest: compound 1; then compounds 4 and 2 (each within the scatter of the next). At a limit, above all of these: compound 3.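

In this assay, among these compounds, the one measured exchange on this aromatic carbon of the five-membered aromatic ring with 3 nitrogen gives a 1.2-fold lower number from compound 2 to compound 4 (0.09 log units; within the scatter), so on the free phenol core the two aryl groups cannot be told apart. The hydrogen-bond acceptor counted on pyridin-2-yl is absent from 4-(trifluoromethyl)phenyl, and the entering group has more heavy atoms, yet the read-out does not move beyond the scatter. Nothing shown here gives a reason for this outcome.

On these data alone, it remains open whether the same exchange would read alike with the (4-methylphenyl)sulfonyl group on the oxygen, as in compound 1. Also open, as far as these compounds go, is how this carbon would respond to a group other than an aryl, such as an aliphatic amine or a carboxylic acid.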